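Amide-linked triaryl imidazoles: tetrazolylsulfanyl to piperazinyl step

The source may report more compounds than this note shows. Statements on the series, on what has been measured and on what is new or still open speak of the compounds shown alone.

Measured so far in a functional assay on MCF7 cells (Homo sapiens) for cytotoxicity, read by MTT assay, with a stated time of 24 h, tested at 6.4 ug/mL; on this read-out lower numbers stand for a weaker effect and higher numbers for a stronger effect at the one concentration tested:
compound 1 `Cc1ccc2oc(SCC(=O)Nc3ccc(-c4nc(-c5ccccc5)c(-c5ccccc5)n4C)cc3)nc2c1` gives 24.6%
compound 2 `Cn1c(-c2ccc(NC(=O)CSc3nc4ccccc4s3)cc2)nc(-c2ccccc2)c1-c1ccccc1` gives 27%
compound 3 `Cn1nnnc1SCC(=O)Nc1ccc(-c2nc(-c3ccccc3)c(-c3ccccc3)n2C)cc1` gives 55.9%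

Compound 3 stands highest of the three numbers in this assay; its nearest neighbour is compound 2, with a number 28.9 percentage points higher from compound 2 to compound 3 (beyond the scatter), and its furthest is compound 1, with a number 31.3 percentage points higher from compound 1 to compound 3 (beyond the scatter). Compound 1 and compound 2 are close to each other, with a number 2.4 percentage points higher from compound 1 to compound 2 (within the scatter).

Compound 4 `CN(C)/C=C/N1CCN(CC(=O)Nc2ccc(-c3nc(-c4ccccc4)c(-c4ccccc4)n3C)cc2)CC1` has not been measured. It differs from compound 3 as follows: 4-(2-(dimethylamino)ethenyl)piperazin-1-yl in place of (1-methyl-1H-tetrazol-5-yl)sulfanyl on a saturated chain carbon bound to a carbonyl carbon. The three measured steps all exchange one heterocycle for another on a sulfur that is kept; none of them removes the sulfur or brings in a piperazine. The two steps that reach compound 3 show that the tetrazole is the best of the three sulfur substituents tested, so leaving it is more likely to cost than to gain, but the size cannot be read from the series. A downward step of moderate size is expected, a number 17.9 percentage points lower from compound 3 to compound 4 (beyond the scatter), with wide uncertainty. Compound 4 is estimated at 38%, within 15% to 62%.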

Compound 4, a percentage reported as activity, at one concentration (the size of the read-out at that concentration, not a potency): 11.1%
For compound 4 the middle estimate is 26.9 percentage points above the measured one; measured number below the stated range.
By their numbers in this assay, from the lowest: compound 4; then compounds 1 and 2 (each within the scatter of the next); then compound 3.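

In this assay, among these compounds, the first change at this position that removes the sulfur and brings in a piperazine gives a number 44.8 percentage points lower from compound 3 to compound 4 (beyond the scatter) as its step from the best sulfur substituent. The same replacement also gives a number 15.9 percentage points lower from compound 2 to compound 4 (beyond the scatter) and a number 13.5 percentage points lower from compound 1 to compound 4 (beyond the scatter) when set against the two fused sulfur substituents, so the 4-(2-(dimethylamino)ethenyl)piperazin-1-yl group falls short of all three sulfanyl groups shown, on a saturated chain carbon bound to a carbonyl carbon. No supporting measurement bears on why the number falls.

Going by these compounds, the step changes the sulfur, the tetrazole and the piperazine together, and which of these carries the loss stays open. An unsubstituted piperazin-1-yl or a plain dimethylamino group at the same place would separate the ring from the ethenyl arm.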